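The compounds below may be only part of what the source reports. "The series", "measured", "known", "first", "only" and "open" are said of these compounds alone.

Measured so far in a functional assay on KBVIN cells (Homo sapiens) for antiproliferative activity, read by sulforhodamine B assay, with a stated time of 3 days; on this read-out higher numbers stand for an effect only at larger amounts of compound and lower numbers for an effect already at smaller amounts:
compound 1, `CCC1=C(O)c2c(oc(-c3ccc(OC)cc3)cc2=O)C(CC)(CC)C1=O`: 0.68 uM
compound 2, `CCC1=C(O)c2c(oc(-c3ccc(CBr)cc3)cc2=O)C(CC)(CC)C1=O`: 27.9 uM
compound 3, `CCC1=C(O)c2c(oc(-c3ccc(C)c(C)c3)cc2=O)C(CC)(CC)C1=O`: 0.71 uM

Compound 3 holds the second highest of the three numbers. The gap to the nearest number is a 1.0-fold higher number from compound 1 to compound 3 (0.02 log units; within the scatter), within the scatter, and the gap to the furthest is a 39-fold lower number from compound 2 to compound 3 (1.59 log units; beyond the scatter).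

The next compound in the series is compound 4, `CCC1=C(O)c2c(oc(-c3cccc(C)c3C)cc2=O)C(CC)(CC)C1=O`. The change from compound 3 is 2,3-dimethylphenyl in place of 3,4-dimethylphenyl on an aromatic carbon: the same atoms, joined differently, at the same aromatic carbon of the shared core.

Of the measured steps, only a 1.0-fold higher number from compound 1 to compound 3 (0.02 log units; within the scatter) concerns this aromatic carbon, and that exchange of a 4-methoxyphenyl for a 3,4-dimethylphenyl stayed within the scatter. The large step of a 41-fold higher number from compound 1 to compound 2 (1.61 log units; beyond the scatter) involves a bromomethyl group, which compound 4 does not carry, so it does not bear on this change. Going by the values given here, no measured step moves a methyl from one place on the phenyl ring to another, so there is no direct precedent.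

The expectation for compound 4 is therefore a step of a 1.4-fold higher number from compound 3 to compound 4 (0.15 log units; within the scatter), not beyond the scatter. Compound 4 is estimated at 1 uM in this assay, with a range from 0.4 uM to 2.8 uM.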

Compound 4, concentration for half-maximal effect: 0.85 uM
Compound 4: the middle estimate sits 1.2-fold (0.07 log units) above what was measured, and the stated range covers the measured number.
By their numbers in this assay, from the lowest: compounds 1, 3 and 4 (each within the scatter of the next); then compound 2.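

In this assay, going by these compounds alone, the first pair of isomers at this aromatic carbon shows that rearranging the two methyls from 3,4-dimethylphenyl to 2,3-dimethylphenyl gives a 1.2-fold higher number from compound 3 to compound 4 (0.08 log units; within the scatter), so this change of arrangement on the phenyl ring does not separate the two compounds. The 2,3-dimethylphenyl group also stays level with 4-methoxyphenyl (a 1.3-fold higher number from compound 1 to compound 4 (0.10 log units; within the scatter)), while the gap to the 4-(bromomethyl)phenyl group remains large (a 33-fold lower number from compound 2 to compound 4 (1.52 log units; beyond the scatter)), so compound 2 alone stands apart among the four compounds. No supporting measurement is available to explain either the lack of separation among compounds 1, 3 and 4 or the separate standing of compound 2.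

The compounds shown leave open whether an amine or a carboxylic acid on this phenyl ring would stay level with compounds 1, 3 and 4 or move towards compound 2. They also do not separate the contribution of the bromine from that of the carbon carrying it, a question that a 4-ethylphenyl or 4-(chloromethyl)phenyl group at this aromatic carbon could address.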